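A few compounds are considered here, and "the series" means these few. Any claim that something is new, unique, unknown or untested is made for them only; others in the source may bear on it.

Compound 1 `CCOc1cccc(/C=N/NC(=O)c2cnccn2)c1` gives in an ADME assay on J774 cells (Mus musculus) for cytotoxicity, read by MTT assay, with a stated time of 48 h, tested at 150 ug/mL (a higher number here means a weaker effect of the compound at the concentration tested, a lower number a stronger effect), 69%
Compound 2 `CCOc1ccc(/C=N/NC(=O)c2cnccn2)cc1` gives in this assay 100%
Compound 3 `O=C(N/N=C/c1cccc(O)c1)c1cnccn1` gives in this assay 88%

Of the compounds shown here, three have been measured in this assay. Compound 2 stands highest of the three, and its gap to compound 3 and to compound 1 is in each case beyond the usual scatter. Compound 1 and compound 2 are built from the same atoms joined differently; the difference between the two cores is not broken down here.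

One change is seen directly: from compound 1 to compound 3 the change is hydrogen in place of ethyl on an oxygen on an aromatic ring and the step in this assay is a number 19 percentage points higher from compound 1 to compound 3 (beyond the scatter). Compound 4 `O=C(N/N=C/c1ccc(O)cc1)c1cnccn1` has not yet been measured. It differs from compound 2 by hydrogen in place of ethyl on an oxygen on an aromatic ring, the same change as from compound 1 to compound 3, at the same kind of place.

In this assay compound 4 is therefore expected to lie close to compound 2, with a step of no change at the digits printed from compound 2 to compound 4 (within the scatter), smaller than the earlier step, because compound 2 already gives 100% and a read-out of this kind has little room above that. The expectation rests on a single earlier step, seen in one pair, which may not carry over to a different core. Compound 4 is estimated at 100%, expected to fall between 88% and 112%.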

Compound 4, a percentage reported as activity, at one concentration (the size of the read-out at that concentration, not a potency): 80%
The estimate for compound 4 lay 20 percentage points above the measured number, outside the stated range (below it).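

On the core of compound 2, hydrogen in place of ethyl on an oxygen on an aromatic ring gives in this assay a number 20 percentage points lower from compound 2 to compound 4 (beyond the scatter) and so runs against the earlier step instead of repeating it. Read side by side, the two steps show that in this series neither the size nor the direction of this change can be carried from one core to the other: the same change on two cores in this assay, a number 19 percentage points higher (beyond the scatter) from compound 1 to compound 3 and a number 20 percentage points lower (beyond the scatter) from compound 2 to compound 4, 39 percentage points apart, beyond the scatter of two such steps.

This does not show why the two cores part ways or which core is the exception, since each core offers a single pair and the result rests on two steps in one assay.

The compounds shown leave open whether a methyl or a propyl group on the same oxygen would follow the ethyl compounds or the hydroxy compounds on either core. They also leave open what an amine or a carboxylic acid in place of the ethoxy group would do in this assay and whether such a group would likewise move in opposite directions on the two cores.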